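A few compounds are considered here, and "the series" means these few. Any claim that something is new, unique, unknown or untested is made for them only; others in the source may bear on it.

Compound 3 `Cc1cc2c(c(Oc3cccc(NS(=O)(=O)c4ccc(Cl)cc4)c3)n1)C(=O)N(C(C)C)C2=O` gives 99% in a functional assay on HEK293 cells for agonist activity at Glucose-dependent insulinotropic receptor (Homo sapiens), read by cAMP accumulation, with a stated time of 30 min (a higher number here means a larger maximal response, a lower number a smaller maximal response), the lowest of the three values seen here. Compound 2 `Cc1cc2c(c(Oc3cccc(NS(=O)(=O)c4ccc(Cl)cc4)c3)n1)C(=O)NC2=O` gives 109%, and compound 1 `Cc1cc2c(c(Oc3cccc(NS(=O)(=O)c4ccc(Cl)cc4)c3)n1)C(=O)N(C1CC1)C2=O` gives 111%. The measured steps are a number 12 percentage points lower from compound 1 to compound 3 (beyond the scatter), a number 10 percentage points lower from compound 2 to compound 3 (within the scatter) and a number 2 percentage points lower from compound 1 to compound 2 (within the scatter), so every swap at this amide-type nitrogen has moved the maximal response only a little. Compound 4 `Cc1cc2c(c(Oc3cccc(NS(=O)(=O)c4ccc(Cl)cc4)c3)n1)C(=O)N(C1CCCC1)C2=O` differs from compound 3 by cyclopentyl in place of isopropyl on an amide-type nitrogen in a ring. The step that bears most on this is the move from cyclopropyl to isopropyl, a modest loss; a second ring group on the same nitrogen is therefore expected to give at most a small change, a number 5 percentage points higher from compound 3 to compound 4 (within the scatter), likely within the scatter. Compound 4 is estimated at 104%, with a range from 90% to 118%.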

Compound 4, largest response reached (reported as efficacy), in percent of the reference or control that the assay uses: 95%
For compound 4 the middle estimate is 9 percentage points above the measured one, within the range that was stated.
By their numbers in this assay, from the lowest: compounds 4, 3, 2 and 1 (each within the scatter of the next, the first and the last beyond it).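

In this assay, putting cyclopentyl in place of isopropyl on the amide-type nitrogen gives a number 4 percentage points lower from compound 3 to compound 4 (within the scatter), so this larger carbon ring leaves no readable change from the open-chain group. Cyclopentyl can, however, be separated from the two groups at the top of this small set: the steps are a number 14 percentage points lower from compound 2 to compound 4 (beyond the scatter) and a number 16 percentage points lower from compound 1 to compound 4 (beyond the scatter), both modest. Nothing measured here gives a reason for these steps. Still open, from the compounds shown here alone, is how an amine, a carboxylic acid or a longer chain on this nitrogen would behave in this assay.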